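Fluoromethoxy to difluoromethyl: compound 2 to compound 4

The compounds below may be only part of what the source reports. "The series", "measured", "known", "first", "only" and "open" are said of these compounds alone.

In a physicochemical assay for lipophilicity, read by HPLC, in phosphate buffer, measured as octanol-water partition, with a stated time of 1 h, at pH 7.4 (a lower number here means a more polar compound, a higher number a more lipophilic compound), compound 2 (`C[C@@]1(c2cc(NC(=O)c3cnc(OCF)cn3)ccc2F)C=C(CF)OC(N)=N1`) reads 2.6 and compound 3 (`Cc1cc(C#N)cnc1C(=O)Nc1ccc(F)c([C@]2(C)C=C(CF)OC(N)=N2)c1`) reads 2.5 within the scatter of it. Compound 1 (`COCC1=C[C@@](C)(c2cc(NC(=O)c3ccc(C#N)cn3)ccc2F)N=C(N)O1`) reads 2 and lies lower than compound 2 by a gap beyond the scatter.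

Compound 4 (`C[C@@]1(c2cc(NC(=O)c3cnc(C(F)F)cn3)ccc2F)C=C(CF)OC(N)=N1`) carries difluoromethyl in place of fluoromethoxy on an aromatic carbon and so turns 5-(fluoromethoxy)pyrazin-2-yl into 5-(difluoromethyl)pyrazin-2-yl. Going by the values given here, no measured step exchanges these two groups directly. Among the compounds with values here, the one step that touches this part of the structure is larger, with 5-cyano-3-methylpyridin-2-yl in place of 5-(fluoromethoxy)pyrazin-2-yl on a carbonyl carbon, and it gave a number 0.10 log units lower from compound 2 to compound 3 (within the scatter) as its result. That single step is thin support, but it offers no ground for expecting a large move.

In this assay no move beyond the scatter is expected, and the estimated step is a number 0.10 log units lower from compound 2 to compound 4 (within the scatter) and nothing larger. For compound 4 the estimate is 2.5 with an expected range from 2.1 to 2.9 as its limits.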

Compound 4, distribution coefficient: 2.5
Compound 4: middle estimate and measured number agree at the digits printed; the measured number falls inside the stated range.
By their numbers in this assay, from the lowest: compound 1; then compounds 3, 4 and 2 (each within the scatter of the next).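

In this assay, going by these compounds alone, the exchange of fluoromethoxy for difluoromethyl, read alone for the first time, gives a number 0.10 log units lower from compound 2 to compound 4 (within the scatter) even though the one hydrogen-bond acceptor counted in fluoromethoxy is gone. The wider exchange on the carbonyl carbon gives no change at the digits printed from compound 3 to compound 4 (within the scatter) and so adds a third group that this assay does not separate from the other two, which holds for these three compounds only. No independent measurement bears on why these readings stay so close.

From the compounds shown here alone, what an amine or a carboxylic acid on this aromatic carbon would read in this assay stays open. Compound 1 differs from the others in more than one place, so its gap cannot be assigned to any single part of the structure.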